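The source may report more compounds than this note shows. Statements on the series, on what has been measured and on what is new or still open speak of the compounds shown alone.

Measured so far:
compound 1 `COc1ccc(Oc2ccc3cc(NC(=O)c4ccc(OC(C)=O)c(CC=C(C)C)c4)c(=O)oc3c2C)cc1` — in a functional assay on SK-BR-3 cells (Homo sapiens) for antiproliferative activity (a lower number here means a stronger inhibitor, a higher number a weaker inhibitor), compound 1 gives 19500 nM
compound 2 `COc1ccc(Oc2ccc3cc(NC(=O)c4ccc(O)c(CC=C(C)C)c4)c(=O)oc3c2C)cc1` — compound 2 gives 42700 nM
compound 3 `COCOc1ccc(Cc2ccc3cc(NC(=O)c4ccc(OC(C)=O)c(CC=C(C)C)c4)c(=O)oc3c2C)cc1OC` — compound 3 gives 14200 nM

Compound 2 stands highest of the three numbers; compound 1 lies nearest to it, compound 3 furthest.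

The step to compound 4 `CC(C)=CCc1cc(C(=O)Nc2cc3ccc(Cc4ccc(O)cc4)c(C)c3oc2=O)ccc1O` is 4-hydroxybenzyl in place of 4-methoxyphenoxy on an aromatic carbon. Among the measured compounds shown here, the only single-place step measured, a 2.2-fold higher number from compound 1 to compound 2 (0.34 log units; beyond the scatter), concerns the acetyl and does not touch this position. Compound 3 differs from compound 1 in more than one place, so its lower number against compound 1 can only be noted, not assigned to the benzyl linkage. For the measured compounds named here, no measured step bears directly on the change; a small shift downward or none beyond the scatter is expected, as a 1.4-fold lower number from compound 2 to compound 4 (0.15 log units; within the scatter).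

For compound 4 in this assay the expected number is 30000 nM, within 12000 nM to 70000 nM.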

Compound 4, half-maximal inhibitory concentration: 21500 nM
The estimate for compound 4 lay 1.4-fold (0.14 log units) above the measured number; the measured number falls inside the stated range.
By their numbers in this assay, from the lowest: compounds 3, 1, 4 and 2 (each within the scatter of the next, the first and the last beyond it).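

In this assay, among the compounds shown here, replacing 4-methoxyphenoxy with 4-hydroxybenzyl on the aromatic carbon ortho to the methyl group gives a step within the scatter (a 2.0-fold lower number from compound 2 to compound 4 (0.30 log units; within the scatter)), the first single-place reading at this position. The two groups differ in their counts, with 1 hydrogen-bond donor entering, yet the number does not move beyond the scatter. No evidence on hand bears on this result.

From the compounds shown here alone, the step changes the linkage and the ring substituent together, so their separate contributions stay open. Also open, going by these compounds, is what a carboxylic acid or an amine on this carbon would give.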